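This account rests on a few compounds, and the source may have more. Where it says the series, first, only, none or still open, it means among the compounds named here.

Measured so far in an assay on CHO cells for displacement of a labelled ligand from adenosine receptor A1 (Homo sapiens), read by scintillation counting, with a stated time of 90 min; on this read-out higher numbers stand for weaker inhibition and lower numbers for stronger inhibition:

Compound 1 `CC(C)COc1ccc(-c2c(C#N)c(N)nc(SCC(N)=O)c2C#N)cc1`: 603 nM
Compound 2 `C=C(C)COc1ccc(-c2c(C#N)c(N)nc(SCC(N)=O)c2C#N)cc1`: 872 nM
Compound 3 `N#Cc1c(N)nc(SCc2ccn[nH]2)c(C#N)c1-c1ccc(OCC2CC2)cc1`: 552 nM

Compound 2 stands at the upper end of the three numbers, but none of the three lies beyond the usual scatter of the others, so the set reads as flat. Going by the values given here, the one step measured at the same place is a 1.4-fold higher number from compound 1 to compound 2 (0.16 log units; within the scatter), which swaps isopropyl for 1-methylethenyl on the saturated chain carbon bound to the oxygen on the aromatic ring and does not move the number beyond the scatter. Compound 3 differs from compound 2 at two places at once, so only its value can be set beside compound 2, and the two are close.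

Compound 4 `CCOc1ccc(-c2c(C#N)c(N)nc(SCC(N)=O)c2C#N)cc1` is not yet measured. Its difference from compound 2 is methyl in place of 1-methylethenyl on a saturated chain carbon bound to an oxygen on an aromatic ring. Among the compounds with values here, no measured step shortens the chain at this place; the only step there, from compound 1 to compound 2, was within the scatter. The expectation is therefore a step of a 1.1-fold lower number from compound 2 to compound 4 (0.04 log units; within the scatter), with no change beyond the scatter. For compound 4 the estimated value is 800 nM, expected to fall between 300 nM and 2500 nM.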

Compound 4, inhibition constant: 345 nM
The estimate for compound 4 lay 2.3-fold (0.37 log units) above the measured number; low and high end bracket the measured number.
By their numbers in this assay, from the lowest: compounds 4, 3, 1 and 2 (each within the scatter of the next, the first and the last beyond it).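

In this assay, the group on the saturated chain carbon bound to the oxygen on the aromatic ring now gives a step beyond the scatter: replacing 1-methylethenyl with methyl gives a 2.5-fold lower number from compound 2 to compound 4 (0.40 log units; beyond the scatter). Replacing isopropyl with methyl at the same place gives a 1.7-fold lower number from compound 1 to compound 4 (0.24 log units; within the scatter), which stays within the scatter, so the lower number for the ethoxy compound is resolved only against the (2-methylprop-2-en-1-yl)oxy compound, and compound 1 goes against any general trend. Nothing available explains this difference between the two steps.

Still open, from the compounds shown here alone, is whether a methoxy group, a straight propoxy or longer chain, or a chain ending in an amine would extend this trend or reverse it. Also open, going by these compounds, is how the ethoxy group behaves with other groups on the sulfur of the shared core.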